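The source may report more compounds than this note shows. Statements on the series, on what has been measured and on what is new or still open speak of the compounds shown alone.

Working notes on the series, read in an ADME assay on microsomes from liver (Mus musculus, strain CD-1) for metabolic stability, read by LC-MS, tested at 2 uM; on this read-out higher numbers stand for a longer-lived compound and lower numbers for a shorter-lived compound

- compound 1 `CNS(=O)(=O)c1ccccc1Nc1cc(-c2ccc3ccn(C)c3c2)c2nccnc2c1` gives 0.2 h
- compound 2 `CN1CCC(NS(=O)(=O)c2ccccc2Nc2cc(-c3ccc4ccn(C)c4c3)c3nccnc3c2)C1` gives 0.667 h
- compound 3 `Cn1cc(CNS(=O)(=O)c2ccccc2Nc2cc(-c3ccc4ccn(C)c4c3)c3nccnc3c2)cn1` is still unmeasured

Of the two measured compounds, compound 2 stands highest at 0.667 h. The move to compound 3 is (1-methyl-1H-pyrazol-4-yl)methyl in place of 1-methylpyrrolidin-3-yl on a sulfonamide nitrogen, with (1-methyl-1H-pyrazol-4-yl)methyl in place of 1-methylpyrrolidin-3-yl on a sulfonamide nitrogen. Going by the values given here, one measured step bears on this place: a 3.3-fold higher number from compound 1 to compound 2 (0.52 log units; beyond the scatter), which is modest. Among the compounds with values here, it offers no direct precedent for the entering group, so no shift beyond the scatter is expected, with a slight lean downward. The expected step is a 1.5-fold lower number from compound 2 to compound 3 (0.17 log units; within the scatter). For compound 3 the estimate is 0.45 h, with an expected range of 0.17 h to 1.2 h.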

Compound 3, half-life: 0.267 h
Estimate against measurement, compound 3: 1.7-fold (0.23 log units) above; measured number inside the range.
By their numbers in this assay, from the lowest: compounds 1 and 3 (each within the scatter of the next); then compound 2.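

In this assay the step of a 2.5-fold lower number from compound 2 to compound 3 (0.40 log units; beyond the scatter) shows that this place on the sulfonamide nitrogen tells the two rings apart. With a 1.3-fold higher number from compound 1 to compound 3 (0.13 log units; within the scatter), (1-methyl-1H-pyrazol-4-yl)methyl does not separate from the methyl of compound 1, so the larger group alone does not carry the rise seen with compound 2. Nothing measured here accounts for the difference between the two groups.

Open, from the compounds shown here alone, is whether the rise with compound 2 follows the ring nitrogen of 1-methylpyrrolidin-3-yl or the saturated ring itself. A cyclopentyl group or a 2-(dimethylamino)ethyl chain at this place would separate the two.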